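Taking the methoxy group off compound 2

The compounds below may be only part of what the source reports. "The series", "measured", "known", "first", "only" and "open" are said of these compounds alone.

In a functional assay on the whole organism with Mus musculus as the target (a lower number here means that less compound is needed, a higher number that more compound is needed for the effect), compound 2 (`COc1ccc(-c2nn(C)c(=S)n2C)cc1`) gives > 25 mg/kg as a limit and not a number. Compound 1 (`Cn1nc(-c2ccccc2)n(C)c1=O`) gives > 50 mg/kg as a limit too. Compound 3 (`Cn1nc(-c2c(Cl)cccc2Cl)n(C)c1=S`) gives > 50 mg/kg as a limit as well. Going by the values given here, with only limits measured, compound 2 cannot be ranked against the other two, and no measured step shows how far a single change moves the dose. Compound 4 (`Cn1nc(-c2ccccc2)n(C)c1=S`) has hydrogen in place of methoxy on an aromatic carbon. In this assay the estimated step that the limit leaves unreadable from compound 2 to compound 4 is expected to stay within the usual scatter, with no firm direction. For compound 4 the estimate is 30 mg/kg as the expected dose, with 10 mg/kg to 60 mg/kg as its expected range.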

Compound 4, dose for half-maximal effect: 0.15 mg/kg
Estimate against measurement, compound 4: 200-fold (2.30 log units) above, and the stated range ends above it.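

In this assay, hydrogen in place of methoxy gives an at least 160-fold lower number from compound 2 to compound 4 (2.22 log units; beyond the scatter). Where the earlier compounds gave only limits, this shows that one change at this place on the six-membered aromatic ring can turn a compound with no readable dose into one with a low, measured dose. The true size of the step stays unknown, as one end of it is a limit: the limit of > 25 mg/kg in this assay, at which 1 of the 4 values shown sits.

Only hydrogen and methoxy appear at this place. From the compounds shown here alone, whether an amine, a carboxylic acid or a longer chain there would keep the dose as low as in compound 4 remains open.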